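Swapping Methoxy for Methyl on the Anilino Ring

The compounds below may be only part of what the source reports. "The series", "measured", "known", "first", "only" and "open" are said of these compounds alone.

Of the compounds shown here, two sharing one core have been measured. Compound 1 `COc1cc(-c2nc(SCc3cn(CC(=O)NC(=O)Nc4ccccn4)nn3)nc(Nc3ccc(C)cc3)c2C#N)cc(OC)c1OC` gives 21300 nM in a functional assay on ECa-109 cells (Homo sapiens) for inhibition, read by MTT assay, with a stated time of 72 h; on this read-out higher numbers stand for weaker inhibition and lower numbers for stronger inhibition. Compound 2 `COc1ccc(Nc2nc(SCc3cn(CC(=O)NC(=O)Nc4ccccn4)nn3)nc(-c3ccc(C)cc3)c2C#N)cc1` has the lowest number of the two, giving 5870 nM in this assay, while compound 1 sits at a number higher by an amount beyond the usual scatter; the two differ in more than one place, so their values are simply reported side by side. Compound 3 `Cc1ccc(Nc2nc(SCc3cn(CC(=O)NC(=O)Nc4ccccn4)nn3)nc(-c3ccc(C)cc3)c2C#N)cc1` is not yet measured. It differs from compound 2 in one change only, (methyl in place of methoxy on an aromatic carbon). For the measured compounds named here, no pair of measured compounds shows the effect of this exact change, so the expected step from compound 2 to compound 3 is small, a 1.1-fold higher number from compound 2 to compound 3 (0.04 log units; within the scatter), most likely within the scatter rather than a clear shift in either direction. Compound 3 is therefore expected to give about 6500 nM in this assay, with a range from 2500 nM to 16000 nM.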

Compound 3, half-maximal inhibitory concentration: > 64000 nM
Compound 3: a limit, no number; the forecaster's own chance of this, stated with the estimate: 5%; at least 9.8-fold (0.99 log units) between middle value and limit.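

In this assay compound 3 gives > 64000 nM, which is a limit of the assay and not a number. With the rest of the structure held constant, going from 4-methoxyphenyl to 4-methylphenyl on the amino group brings an at least 10-fold higher number from compound 2 to compound 3 (1.03 log units; beyond the scatter), so this carbon, para to a large group, is not indifferent to methoxy against methyl. The (4-methylphenyl)amino group does not by itself remove a measurable value, since with 4-methylphenyl in place of 3,4,5-trimethoxyphenyl on the other side there is an at least 3.0-fold higher number from compound 1 to compound 3 (0.47 log units; beyond the scatter), and the result therefore depends on the group at that second place as well.

From the compounds shown here alone, it remains open whether a hydroxyl, a fluorine or an amine on the same carbon would behave like methoxy or like methyl. Going by these compounds, how far compound 3 lies past its limit also stays unknown, so the full size of both steps cannot be given.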